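The source may report more compounds than this note shows. Statements on the series, on what has been measured and on what is new or still open speak of the compounds shown alone.

Measured so far in a functional assay on HeLa cells (Homo sapiens) for inhibition, read by CCK-8 assay, with a stated time of 48 h (a lower number here means a stronger inhibitor, a higher number a weaker inhibitor), are these values
- compound 1 `COc1cc(-c2ccnc3cc(-c4ccc(Cl)cc4)nn23)cc(OC)c1OC` with 1490 nM
- compound 2 `COc1cc(-c2ccnc3cc(-c4ccc(C)cc4)nn23)cc(OC)c1OC` with 21 nM
- compound 3 `Cn1ccc2cc(-c3cc4nccc(-c5ccc(F)cc5)n4n3)ccc21` with 5210 nM

Compound 1 stands in the middle of these three numbers. Its value lies above that of compound 2 and below that of compound 3, and both gaps are beyond the scatter.

Within the data shown here, still unmeasured is compound 4 `COc1cc(-c2ccnc3cc(-c4cn(C)c5ccccc45)nn23)cc(OC)c1OC` which keeps the core of compound 1 and carries 1-methyl-1H-indol-3-yl in place of 4-chlorophenyl on an aromatic carbon as its one change.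

Among the measured compounds shown here, one measured step bears on this change. Methyl in place of chloro on that same 4-chlorophenyl group gave a 71-fold lower number from compound 1 to compound 2 (1.85 log units; beyond the scatter) and that counts as a large step. Compound 3 differs from compound 1 in more than one place, so it offers no clean comparison. For the measured compounds named here, no measured pair shows this exact swap, which leaves the size uncertain.

A lower number is expected in this assay since compound 2 at 21 nM shows how low this core can go without the chloro. The entering group is no simple methyl, so a smaller step is expected. The estimate amounts to an expected 9.9-fold lower number from compound 1 to compound 4 (1.00 log units; beyond the scatter) overall. For compound 4 the estimated value is 150 nM with an expected range from 20 nM to 1100 nM in this assay.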

Compound 4, half-maximal inhibitory concentration: 399 nM
Compound 4: the middle estimate sits 2.7-fold (0.42 log units) below what was measured; the measured number falls inside the stated range.
By their numbers in this assay, from the lowest: compound 2; then compound 4; then compound 1; then compound 3.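

In this assay, this aromatic carbon of the shared core accepts a group with two fused aromatic rings, not just a single substituted benzene ring: 1-methyl-1H-indol-3-yl in place of 4-chlorophenyl gives a 3.7-fold lower number from compound 1 to compound 4 (0.57 log units; beyond the scatter), a modest gain. The same group does not match 4-methylphenyl, however, and replacing that group with it gives a 19-fold higher number from compound 2 to compound 4 (1.28 log units; beyond the scatter), so the gain over the chloro compound recovers only part of what the simple methyl achieved. Among these three compounds, the group at this one place therefore sets a clear order, with 4-methylphenyl giving the lowest number, 1-methyl-1H-indol-3-yl the middle one and 4-chlorophenyl the highest, and nothing measured here explains that order.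

On these data alone, it remains open whether an ethyl group in place of the methyl on the phenyl ring, or an amine there, would keep a number as low as that of compound 2. The compounds shown also leave open how much of the result for compound 4 depends on the methyl group of 1-methyl-1H-indol-3-yl, since the same group with hydrogen in place of that methyl does not appear among them.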